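The compounds below may be only part of what the source reports. "The series", "measured", "known", "first", "only" and "open" are said of these compounds alone.

Compound 1 `NCCCOc1ccc([C@H]2CC[C@]3(CC2)OOC2(O3)C3CC4CC(C3)CC2C4)cc1` gives < 7 mL.min-1.g-1 in an ADME assay on microsomes from liver (Homo sapiens) for metabolic stability, read by LC-MS, tested at 1 uM (a higher number here means faster removal of the compound, a lower number slower removal), a limit of the assay.
Compound 2 `CC(C)(CN)Oc1ccc([C@H]2CC[C@]3(CC2)OOC2(O3)C3CC4CC(C3)CC2C4)cc1` gives < 7 mL.min-1.g-1 in this assay, a limit of the assay.
Compound 3 `CC(C)(N)CCOc1ccc([C@H]2CC[C@]3(CC2)OOC2(O3)C3CC4CC(C3)CC2C4)cc1` gives < 7 mL.min-1.g-1 in this assay, a limit of the assay.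

Compound 2 stands at a limit in this assay, and the two other values shown are limits as well, so none of the three can be ranked against another; all three sit at the limit of < 7 mL.min-1.g-1 in this assay, at which 3 of the 3 values shown sit. The step to be followed leads to compound 4 `CC1(C)CC(O)(COc2ccc([C@H]3CC[C@]4(CC3)OOC3(O4)C4CC5CC(C4)CC3C5)cc2)CC(C)(C)N1`, in which ((4-hydroxy-2,2,6,6-tetramethylpiperidin-4-yl)methyl in place of 1-(aminomethyl)-1-methylethyl on an oxygen on an aromatic ring). Within the data shown here, two measured steps touch the same oxygen on an aromatic ring: a step that the two limits leave unreadable from compound 1 to compound 2 and a step that the two limits leave unreadable from compound 2 to compound 3. Neither gives a readable size, since both start and end at a limit, and the third step, a step that the two limits leave unreadable from compound 1 to compound 3, is likewise unreadable. Nothing in these numbers therefore sets a direction for the change in compound 4, and the expectation can only rest on the fact that every measured compound of this core stays at the limit. Compound 4 is expected to give 6 mL.min-1.g-1, within 3 mL.min-1.g-1 to 15 mL.min-1.g-1, in this assay. That estimate means a step that the limit leaves unreadable from compound 2 to compound 4 from compound 2 to compound 4, which is expected to be no larger than the scatter.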

Compound 4, intrinsic clearance in microsomes: 14 mL.min-1.g-1
The estimate for compound 4 lay 2.3-fold (0.37 log units) below the measured number; the measured number falls inside the stated range.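

In this assay, compound 4 is the only compound shown that gives a number rather than a limit, so (4-hydroxy-2,2,6,6-tetramethylpiperidin-4-yl)methyl on the oxygen on the aromatic ring is the one group here with a readable value. Against the earlier compounds the data give an at least 2.0-fold higher number from compound 2 to compound 4 (0.30 log units; that floor lies within the scatter), an at least 2.0-fold higher number from compound 3 to compound 4 (0.30 log units; that floor lies within the scatter) and an at least 2.0-fold higher number from compound 1 to compound 4 (0.30 log units; that floor lies within the scatter); each of these is only a floor, so the full size of the steps stays unknown. The steps among compound 1, compound 2 and compound 3 cannot be read, and those compounds remain where they stood: the limit of < 7 mL.min-1.g-1 in this assay, at which 3 of the 4 values shown sit.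

The compounds shown leave open whether the number of compound 4 goes with the hydroxy group, with the methyl groups on the ring or with the ring itself. An unsubstituted piperidine or an open-chain amino alcohol on the same oxygen would bear on that question.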